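A few compounds are considered here, and "the series" means these few. Any claim that something is new, unique, unknown or untested is made for them only; others in the source may bear on it.

Compound 1 `CCCC(=O)Nc1c(C(O)(C(F)(F)F)C(F)(F)F)ccc2ccccc12` in an assay on LtK cells with ATP-sensitive inward rectifier potassium channel 11 (Homo sapiens) as the target (on this read-out higher numbers stand for an effect only at larger amounts of compound and lower numbers for an effect already at smaller amounts), gives 131 nM. Compound 2 `O=C(Nc1c(C(O)(C(F)(F)F)C(F)(F)F)ccc2ccccc12)c1cccc(Cl)c1Cl` in this assay gives only a limit, > 10000 nM. Among the measured compounds shown here, the step of an at least 76-fold higher number from compound 1 to compound 2 (1.88 log units; beyond the scatter) is therefore the only measured step, and compound 2 stands at the limit of > 10000 nM in this assay, at which 1 of the 2 values shown sits, with no number of its own. Compound 3 `O=C(Nc1c(C(O)(C(F)(F)F)C(F)(F)F)ccc2ccccc12)c1cccnc1` differs from compound 2 by pyridin-3-yl in place of 2,3-dichlorophenyl on a carbonyl carbon. The measured step from propyl to an aromatic ring on the carbonyl carbon bears on this change only in that a carbonyl-bound aromatic ring pushed compound 2 to the limit; a second aromatic ring in the same position gives no measured reason to expect a return toward compound 1. Compound 3 is expected to stay near compound 2, with an expected step of an at least 1.1-fold lower number from compound 2 to compound 3 (0.04 log units; that floor lies within the scatter). The estimate for compound 3 in this assay is 9000 nM, between 2000 nM and 30000 nM.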

Compound 3, half-maximal effective concentration: 60 nM
Compound 3: middle estimate off by 150-fold (2.18 log units), on the high side; the measured number lies below the stated range.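

Pyridin-3-yl on the carbonyl carbon restores the effect lost with 2,3-dichlorophenyl in this assay (an at least 160-fold lower number from compound 2 to compound 3 (2.22 log units; beyond the scatter)), so an aromatic ring at this place does not by itself end the effect. Compound 3 also acts at smaller amounts than the propyl amide (a 2.2-fold lower number from compound 1 to compound 3 (0.34 log units; beyond the scatter)), a modest step but one beyond the scatter, so the propyl chain is not required here. Compound 2 holds only a limit, so the step out of it is a floor: the limit of > 10000 nM in this assay, at which 1 of the 3 values shown sits.

The compounds shown do not separate the gain from the ring nitrogen of pyridin-3-yl from the removal of the two chlorines, a question that plain phenyl or 3-chlorophenyl on the same carbonyl carbon would address. On these data alone, how pyridin-2-yl, pyridin-4-yl or a longer chain in place of propyl would read also stays open.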